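This account rests on a few compounds, and the source may have more. Where it says the series, first, only, none or still open, it means among the compounds named here.

Measured so far in a functional assay on WI-38 VA13 cells (Homo sapiens) for cytotoxicity; a lower number here means that less compound is needed, a higher number that more compound is needed for the effect:
compound 1, `NCCC(=O)Nc1nc2ccc(NC(=O)c3c(Cl)cccc3Cl)cc2s1`: 5.3 ug/mL
compound 2, `COCCOC(=O)Nc1nc2ccc(NC(=O)c3c(Cl)cccc3Cl)cc2s1`: 0.011 ug/mL
compound 3, `CC(C)NC(=O)Nc1nc2ccc(NC(=O)c3c(Cl)cccc3Cl)cc2s1`: 0.03 ug/mL

Within this set compound 3 stands second highest of the three numbers in this assay. Its nearest neighbour is compound 2, a 2.7-fold higher number from compound 2 to compound 3 (0.44 log units; beyond the scatter), and the furthest is compound 1, a 180-fold lower number from compound 1 to compound 3 (2.25 log units; beyond the scatter). The two steps away from compound 1, a 480-fold lower number from compound 1 to compound 2 (2.68 log units; beyond the scatter) and a 180-fold lower number from compound 1 to compound 3 (2.25 log units; beyond the scatter), show that what the ring nitrogen of the shared core carries moves this assay strongly.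

Compound 4, `COc1ccc(Nc2nc3ccc(NC(=O)c4c(Cl)cccc4Cl)cc3s2)cc1`, is not yet measured. The change from compound 3 is 4-methoxyphenyl in place of isopropylcarbamoyl on a nitrogen on an aromatic ring. For the measured compounds named here, none of the measured steps makes a change of this kind: all three keep a carbonyl on that nitrogen and vary only what sits on the carbonyl carbon, whereas in compound 4 the carbonyl is gone and an aromatic ring stands on the nitrogen directly. The measured steps therefore bear on it only by showing how sensitive this assay is to this position; they give no direction. Taking the large steps from compound 1 together with the modest gap between compound 2 and compound 3 as the only guide, compound 4 is expected to fall between compound 1 and compound 3 in this assay, which means an expected step of a 5.0-fold higher number from compound 3 to compound 4 (0.70 log units; beyond the scatter). The estimate for compound 4 is 0.15 ug/mL, expected to lie between 0.015 ug/mL and 1.5 ug/mL.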

Compound 4, half-maximal effective concentration: 0.87 ug/mL
Beside the measured number, compound 4's estimate is 5.8-fold (0.76 log units) below it; the measured number falls inside the stated range.
By their numbers in this assay, from the lowest: compound 2; then compound 3; then compound 4; then compound 1.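

In this assay, replacing the carbonyl-linked substituent on this nitrogen with an aromatic ring gives steps much larger than the one seen when only the group on the carbonyl carbon changes: a 29-fold higher number from compound 3 to compound 4 (1.46 log units; beyond the scatter) and a 79-fold higher number from compound 2 to compound 4 (1.90 log units; beyond the scatter), against a 2.7-fold higher number from compound 2 to compound 3 (0.44 log units; beyond the scatter). A carbonyl on the nitrogen is still not enough on its own to give a low number, since the carbonyl-bearing 2-aminoethyl compound lies on the high side of the aryl compound, a 6.1-fold lower number from compound 1 to compound 4 (0.78 log units; beyond the scatter), so the order at this position is set by the whole substituent and not by the presence of the carbonyl alone. No supporting data bear on the reason for these shifts.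

Compound 4 differs from the carbonyl compounds in both the linking carbonyl and the aromatic ring, so the compounds shown do not separate the contribution of each; an isopropyl group placed directly on the nitrogen, or a phenyl ring without the methoxy group, would address that. On these data alone, it also remains open whether the high number of compound 1 follows the terminal amine or the chain itself, which a plain propyl chain or a carboxylic acid on the carbonyl carbon would test.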